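Hydroxyphenyl placement on the shared core: compound 2 to compound 3

The compounds below may be only part of what the source reports. "The series", "measured", "known", "first", "only" and "open" are said of these compounds alone.

Compound 1 `Oc1ccc(-c2cc(-c3cccs3)cc(-c3cccc(O)c3)n2)cc1` carries a 4-hydroxyphenyl and a 3-hydroxyphenyl group with a thiophene; in a functional assay on HCT-15 cells (Homo sapiens) for cytotoxicity, read by CCK-8 assay (a higher number here means a weaker inhibitor, a lower number a stronger inhibitor), compound 1 gives 1770 nM. Compound 2 `Oc1cccc(-c2cc(-c3ccccn3)cc(-c3ccccc3O)n2)c1` carries a 2-hydroxyphenyl and a 3-hydroxyphenyl group with a pyridine. For compound 2 this assay reports only a limit, > 50000 nM, so compound 2 stands at the weak end of what has been measured (the limit of > 50000 nM in this assay, at which 1 of the 2 values shown sits). Compound 3 `Oc1ccc(-c2cc(-c3ccccn3)cc(-c3cccc(O)c3)n2)cc1` is not yet measured in this assay. It differs from compound 2 in one place (4-hydroxyphenyl in place of 2-hydroxyphenyl on an aromatic carbon), the change being made on an aromatic carbon of the core next to the ring nitrogen. The step from compound 2 to compound 3 is expected to move potency toward the value of compound 1 at 1770 nM, since compound 1 also carries the 4-hydroxyphenyl group, and is expected to be an at least 3.3-fold lower number from compound 2 to compound 3 (0.52 log units; beyond the scatter), beyond the usual scatter. Compound 3 is accordingly estimated at 15000 nM, within a range of 3000 nM to 50000 nM.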

Compound 3, half-maximal inhibitory concentration: > 50000 nM
Compound 3 gave a limit, no number; the forecaster's own chance of this, stated with the estimate: 35%; at least 3.3-fold (0.52 log units) between middle value and limit.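

With 4-hydroxyphenyl in place of 2-hydroxyphenyl, compound 3 in this assay still gives only a limit, > 50000 nM, and the step at this position cannot be read. Both compounds with the pyridin-2-yl group give no number: the limit of > 50000 nM in this assay, at which 2 of the 3 values shown sit.

Among these compounds, the one readable change lies elsewhere: with pyridin-2-yl in place of thiophen-2-yl, there is an at least 28-fold higher number from compound 1 to compound 3 (1.45 log units; beyond the scatter), so with the hydroxyphenyl groups of compound 3 held fixed, the exchange of these two groups separates a measurable value from a limit.

Going by these compounds, whether 2-hydroxyphenyl and 4-hydroxyphenyl differ at all with pyridin-2-yl kept stays open, as both readings are limits. Also open, on these data alone, is how an aminophenyl or a carboxyphenyl group at this position would read, and whether 2-hydroxyphenyl gives a number with thiophen-2-yl kept.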